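Changing the ester chain of compound 2

A few compounds are considered here, and "the series" means these few. Any claim that something is new, unique, unknown or untested is made for them only; others in the source may bear on it.

Of the compounds shown here, three built on one shared core have been measured in a functional assay (cardiac atrium) for agonist activity, with Cavia porcellus as the target; a higher number here means that more compound is needed for the effect, a lower number that less compound is needed. They differ only in the pyridyl group attached to a saturated ring carbon. Compound 1 `CC1=NC(C)=C([N+](=O)[O-])C(c2ccccn2)/C1=C(\O)OCC(C)C` gives 9100 nM, compound 2 `CC1=NC(C)=C([N+](=O)[O-])C(c2cccnc2)/C1=C(\O)OCC(C)C` gives 1740 nM, and compound 3 `CC1=NC(C)=C([N+](=O)[O-])C(c2ccncc2)/C1=C(\O)OCC(C)C` gives 8510 nM. Compound 2 has the lowest number of the three: a 5.2-fold lower number from compound 1 to compound 2 (0.72 log units; beyond the scatter) and a 4.9-fold higher number from compound 2 to compound 3 (0.69 log units; beyond the scatter), while a 1.1-fold lower number from compound 1 to compound 3 (0.03 log units; within the scatter).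

Compound 4 `COCCO/C(O)=C1\C(C)=NC(C)=C([N+](=O)[O-])C1c1cccnc1` keeps the pyridin-3-yl group of compound 2 and alters the ester chain instead: methoxymethyl in place of isopropyl on a saturated chain carbon bound to an oxygen on an unsaturated carbon. Among the compounds with values here, none of the measured steps touches this chain; all three concern the pyridyl group, so they offer no direct guide to the size or direction of this change. With nothing in the measured compounds pointing to a shift, compound 4 is expected to show a 1.1-fold higher number from compound 2 to compound 4 (0.06 log units; within the scatter), a step within the scatter. Compound 4 is therefore estimated at 2000 nM, with a range from 700 nM to 6000 nM.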

Compound 4, half-maximal effective concentration: 49400 nM
Compound 4: the middle estimate sits 25-fold (1.39 log units) below what was measured, and the stated range ends below it.
By their numbers in this assay, from the lowest: compound 2; then compounds 3 and 1 (each within the scatter of the next); then compound 4.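

Within the data shown here, the ester chain, which the earlier compounds left untouched, proves to be a sensitive place in this assay: the change gives a 28-fold higher number from compound 2 to compound 4 (1.45 log units; beyond the scatter), a large step, whereas the steps among the pyridyl groups are at most modest. Isopropyl and methoxymethyl have the same count of heavy atoms, so at this place on a saturated chain carbon bound to an oxygen on an unsaturated carbon, exchanging one carbon for an oxygen that counts as a hydrogen-bond acceptor is enough to produce this step. No available evidence explains the size of this step.

A single change cannot show whether the ether oxygen itself matters or whether other chains would behave alike, such as a longer hexyl chain or a chain ending in an amine. As far as these compounds go, it also remains open whether the same change would give a similar step with pyridin-2-yl or pyridin-4-yl in place of pyridin-3-yl.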